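Swapping 3,4-dihydroxyphenyl for 4-bromophenyl

The source may report more compounds than this note shows. Statements on the series, on what has been measured and on what is new or still open speak of the compounds shown alone.

- compound 1 `COc1ccc(C2=C(c3ccc(SC)cc3)CC3CCCN3C2=O)cc1O`: 6000 nM
- compound 2 `CSc1ccc(C2=C(c3ccc(O)c(O)c3)C(=O)N3CCCC3C2)cc1`: 60000 nM

In a functional assay on NCI-H520 cells (Homo sapiens) for cytotoxicity (a lower number here means a stronger inhibitor of growth, a higher number a weaker inhibitor of growth), compound 2 has the higher of the two numbers, 60000 nM. Compound 3 `CSc1ccc(C2=C(c3ccc(Br)cc3)C(=O)N3CCCC3C2)cc1` carries 4-bromophenyl in place of 3,4-dihydroxyphenyl on a double-bonded ring carbon. Among the compounds with values here, only one measured step bears on this change. That modest step, a 10-fold higher number from compound 1 to compound 2 (1.00 log units; beyond the scatter), put hydrogen in place of methyl on an oxygen on the aromatic ring that compound 3 alters. It is thin support, but it points towards a lower number for compound 3. The expected step is a 5.0-fold lower number from compound 2 to compound 3 (0.70 log units; beyond the scatter), of similar size. The estimate for compound 3 is 12000 nM, with a range from 3000 nM to 45000 nM.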

Compound 3, concentration for 50% growth inhibition: 7000 nM
The estimate for compound 3 lay 1.7-fold (0.23 log units) above the measured number; the range from low to high includes it.
By their numbers in this assay, from the lowest: compounds 1 and 3 (each within the scatter of the next); then compound 2.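

In this assay, replacing 3,4-dihydroxyphenyl on this double-bonded ring carbon with 4-bromophenyl gives an 8.6-fold lower number from compound 2 to compound 3 (0.93 log units; beyond the scatter), so this ring need not carry any hydroxyl group. Set against 3-hydroxy-4-methoxyphenyl, the same 4-bromophenyl gives a 1.2-fold higher number from compound 1 to compound 3 (0.07 log units; within the scatter), so among these three compounds only 3,4-dihydroxyphenyl stands apart. No measurement here explains these results. Still open, on these data alone, is how an unsubstituted phenyl ring, or a phenyl ring bearing an amine or a carboxylic acid, would compare at this position.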